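Swapping a Pentyl Chain for a Cyclopentyl Ring

The source may report more compounds than this note shows. Statements on the series, on what has been measured and on what is new or still open speak of the compounds shown alone.

Three compounds have so far been measured in a functional assay on DU-145 cells (Homo sapiens) for cytotoxicity, read by MTT assay, with a stated time of 72 h; on this read-out higher numbers stand for an effect only at larger amounts of compound and lower numbers for an effect already at smaller amounts:

compound 1 `COc1cccc(Nc2cc(-c3ccccc3)oc(=O)c2)c1` gives 0.66 uM
compound 2 `CCCCCc1cc(Nc2ccc(OC)cc2)cc(=O)o1` gives 5.94 uM
compound 3 `O=c1cc(NC2CCCCC2)cc(-c2ccccc2)o1` gives 7.47 uM

Among these three numbers compound 2 holds the second highest. Its nearest neighbour is compound 3, whose number lies within the scatter of that of compound 2, so the two cannot be told apart. Compound 1 stands furthest away, with a number lower than that of compound 2 by a margin beyond the scatter.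

Compound 4 `COc1ccc(Nc2cc(C3CCCC3)oc(=O)c2)cc1` has not yet been measured in this assay. It differs from compound 2 in a single place: cyclopentyl in place of pentyl on an aromatic carbon. The group that leaves and the group that enters match in their count of heavy atoms and both carry no donors or acceptors; what changes is that the chain closes into a ring. Going by the values given here, no measured pair in this set shows such a step, so there is no precedent to draw on. The step is expected to be small, a 1.3-fold lower number from compound 2 to compound 4 (0.12 log units; within the scatter), with no direction that would reach beyond the scatter. Compound 4 is therefore estimated at 4.5 uM in this assay, within a range from 1.5 uM to 14 uM.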

Compound 4, concentration for half-maximal effect: 5.42 uM
For compound 4 the middle estimate is 1.2-fold (0.08 log units) below the measured one; measured number inside the range.
By their numbers in this assay, from the lowest: compound 1; then compounds 4, 2 and 3 (each within the scatter of the next).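

In this assay, closing the pentyl chain into a cyclopentyl ring on the aromatic carbon next to the ring oxygen gives a 1.1-fold lower number from compound 2 to compound 4 (0.04 log units; within the scatter), so the two compounds cannot be told apart. Going by these compounds alone, this is the first pair in the set that differs in one place, and it shows that, for this pair, the open chain and the closed ring are interchangeable at this position on this read-out. Nothing available accounts for this result.

The compounds shown leave open whether a much smaller group such as methyl, a longer chain such as heptyl, or a carboxylic acid at this position would move the number beyond the scatter. They also leave open which single change lies behind the number of compound 1, which differs from both compound 2 and compound 4 in more than one place.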